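Adding a Second Fluorine to Compound 2

A few compounds are considered here, and "the series" means these few. Any claim that something is new, unique, unknown or untested is made for them only; others in the source may bear on it.

Of the compounds shown here, three have been tested in a functional assay on the whole organism (strain Hart Swiss) with Mus musculus as the target, with stated times of 5 days and 2 weeks, at a dose of 80 mg/kg by the intraperitoneal route; on this read-out lower numbers stand for a weaker effect and higher numbers for a stronger effect at the one dose given. Compound 1 `CCNC(=O)/C=C(C)/C=C/C(F)=C(C)/C=C/c1c(C)cc(OC)c(C)c1C` gives 53%, compound 2 `CCOC(=O)/C=C(C)/C(F)=C/C=C(C)/C=C/c1c(C)cc(OC)c(C)c1C` gives 82%, and compound 3 `CCOC(=O)/C=C(C)/C(F)=C\C=C(C)\C=C\c1c(C)cc(OC)c(C)c1C` gives 56%. Compound 2 has the highest of the three numbers, and the drop a number 26 percentage points lower from compound 2 to compound 3 (beyond the scatter) arises because of the fact that compounds 2 and 3 differ only in the configuration as drawn. Compound 4 `CCOC(=O)/C(F)=C(C)/C(F)=C/C=C(C)/C=C/c1c(C)cc(OC)c(C)c1C` differs from compound 2 in one place: a group of 9 heavy atoms (6 carbon, 2 oxygen, 1 fluorine; no ring) in place of a group of 8 heavy atoms (6 carbon, 2 oxygen; no ring), on a double-bonded chain carbon bound to a double-bonded chain carbon and a fluorine atom. Among the measured compounds shown here, no measured step swaps a hydrogen for a fluorine on this part of the chain; the only measured step changes how a double bond is drawn, which is a different kind of change and so does not bear on this one. The step of a number 7 percentage points lower from compound 2 to compound 4 (within the scatter) is therefore expected to lie within the scatter, and compound 4 is estimated at 75%, between 50% and 95%.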

Compound 4, a percentage reported as activity, at one dose (the size of the read-out at that dose, not a potency): 17%
The estimate for compound 4 lay 58 percentage points above the measured number, and the stated range ends above it.
By their numbers in this assay, from the lowest: compound 4; then compounds 1 and 3 (each within the scatter of the next); then compound 2.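

In this assay, placing one fluorine atom on the 2-(ethoxycarbonyl)-1-methylethenyl group gives a number 65 percentage points lower from compound 2 to compound 4 (beyond the scatter). So this group, until now changed only in how a double bond is drawn, does not tolerate every small change to its atoms. Nothing known about these compounds explains the loss.

As far as these compounds go, it remains open whether a chlorine atom or a methyl group on the same carbon would cost as much. From the compounds shown here alone, it is also open whether a carboxylic acid in place of the ethoxycarbonyl part would change the outcome.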